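From a Methyl Sulfonamide to a Phenol Sulfonamide

A few compounds are considered here, and "the series" means these few. Any claim that something is new, unique, unknown or untested is made for them only; others in the source may bear on it.

Of the compounds shown here, two on a shared core have been measured in an assay for inhibition of methylcytosine dioxygenase TET2 (Homo sapiens), read by mass spectrometry, with stated times of 30 min and 1 h; a higher number here means a weaker inhibitor, a lower number a stronger inhibitor. Compound 1 `O=S(=O)(O)c1ccc(F)c2ncc(I)cc12` carries a hydroxy on its sulfonyl sulfur and gives 2300 nM. Compound 2 `CNS(=O)(=O)c1ccc(F)c2ncc(I)cc12` carries a methylamino there instead, and for compound 2 this assay reports > 200000 nM, which is a limit and not a number. Going by the values given here, the single measured step, an at least 86-fold higher number from compound 1 to compound 2 (1.93 log units; beyond the scatter), marks a large loss of potency, and its size rests on the limit (the limit of > 200000 nM in this assay, at which 1 of the 2 values shown sits). Compound 3 `O=S(=O)(Nc1cccc(O)c1)c1ccc(F)c2ncc(I)cc12` keeps the sulfonamide of compound 2 and changes the group on its nitrogen: 3-hydroxyphenyl in place of methyl on a sulfonamide nitrogen. Among the compounds with values here, no measured step covers an exchange of this kind, and the one step at hand leaves compound 2 beyond what this assay resolves. The step from compound 2 to compound 3 is expected to be an at least 2.5-fold lower number from compound 2 to compound 3 (0.39 log units; beyond the scatter), a modest gain at most. Compound 3 is therefore estimated at about 80000 nM, within a range from 5000 nM to 200000 nM.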

Compound 3, half-maximal inhibitory concentration: > 200000 nM
Compound 3 was reported as a limit (the forecaster's own chance of this, stated with the estimate: 50%); middle value at least 2.5-fold (0.39 log units) away from the limit.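

Compound 2 and compound 3 both stand at a limit in this assay, so no step between them can be read: the limit of > 200000 nM in this assay, at which 2 of the 3 values shown sit.

The compounds shown leave open how far each one lies past that limit, and whether 3-hydroxyphenyl in place of methyl on a sulfonamide nitrogen changes potency at all.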